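The source may report more compounds than this note shows. Statements on the series, on what has been measured and on what is new or still open speak of the compounds shown alone.

Compound 2 `COC(=O)C1=C(C)N=C(C)/C(=C(\O)OC)C1c1cccc(C)c1` stands second highest of the three numbers in a functional assay (muscle tissue) with Cavia porcellus as the target; on this read-out higher numbers stand for an effect only at larger amounts of compound and lower numbers for an effect already at smaller amounts: compound 2 gives 110 nM, while compound 1 `C=Cc1ccccc1C1C(C(=O)OC)=C(C)N=C(C)/C1=C(\O)OC` gives 4.47 nM and compound 3 `COC(=O)C1=C(C)N=C(C)/C(=C(\O)OC)C1c1ccc(Br)cc1` gives 540 nM. Compound 4 `COC(=O)C1=C(C)N=C(C)/C(=C(\O)OC)C1c1cccc(C(F)(F)F)c1` differs from compound 2 by trifluoromethyl in place of methyl on an aromatic carbon. Among the compounds with values here, no measured step replaces methyl with trifluoromethyl; each step here exchanges the whole group on the saturated ring carbon, giving a 25-fold higher number from compound 1 to compound 2 (1.39 log units; beyond the scatter), a 120-fold higher number from compound 1 to compound 3 (2.08 log units; beyond the scatter) and a 4.9-fold higher number from compound 2 to compound 3 (0.69 log units; beyond the scatter). The closest comparison, a changed group on the aryl ring, gave only a modest step, so a modest rise, or no step beyond the scatter, in this assay is expected for compound 4. Compound 4 is estimated at 200 nM, between 60 nM and 700 nM, which means an expected 1.8-fold higher number from compound 2 to compound 4 (0.26 log units; within the scatter).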

Compound 4, half-maximal effective concentration: 74.1 nM
The estimate for compound 4 lay 2.7-fold (0.43 log units) above the measured number, within the range that was stated.
By their numbers in this assay, from the lowest: compound 1; then compounds 4 and 2 (each within the scatter of the next); then compound 3.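

In this assay, trifluoromethyl in place of methyl on an aromatic carbon gives a 1.5-fold lower number from compound 2 to compound 4 (0.17 log units; within the scatter), so this position tolerated the exchange without a change beyond the scatter. The earlier steps shown here had only exchanged the whole group on the saturated ring carbon, and each of those went beyond the scatter. Nothing available here accounts for this result. From the compounds shown here alone, whether an amine or a carboxylic acid on this aromatic carbon would also stay within the scatter remains open. So does whether methyl and trifluoromethyl would match each other elsewhere on the aromatic ring.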